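This account rests on a few compounds, and the source may have more. Where it says the series, first, only, none or still open, it means among the compounds named here.

Of the compounds shown here, three sharing one core have been measured in a functional assay on PC-3 cells (Homo sapiens) for inhibition, read by MTT assay, with a stated time of 72 h; on this read-out higher numbers stand for weaker inhibition and lower numbers for stronger inhibition. Compound 1 `O=C(CSc1nc(Nc2ccccc2)c2ccccc2n1)Nc1ccccc1F` gives 12400 nM, compound 2 `O=C(CSc1nc(Nc2ccccc2)c2ccccc2n1)Nc1cccc(Br)c1` gives 11400 nM, and compound 3 `O=C(CSc1nc(Nc2ccccc2)c2ccccc2n1)Nc1ccc(F)cc1` gives 9560 nM. Compound 3 therefore shows the lowest of the three numbers, yet the gaps are small: the step of a 1.3-fold lower number from compound 1 to compound 3 (0.11 log units; within the scatter) and the step of a 1.2-fold lower number from compound 2 to compound 3 (0.08 log units; within the scatter) both lie within the scatter, as does the step of a 1.1-fold lower number from compound 1 to compound 2 (0.04 log units; within the scatter). Across these three compounds the only thing that varies is the group on the amide-type nitrogen, and swapping one substituted phenyl for another has not moved the read-out beyond what repeated measurements would show anyway.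

Compound 4 `O=C(CSc1nc(Nc2ccccc2)c2ccccc2n1)Nc1ccc(F)c(Cl)c1` follows the same path. The change from compound 3 is chloro in place of hydrogen on an aromatic carbon, giving 3-chloro-4-fluorophenyl in place of 4-fluorophenyl, the new chloro sitting ortho to the fluoro group already present. Among the measured compounds shown here, no measured pair adds a group to the phenyl in this way, so the three measured steps are the only guide, and each of them was within the scatter. Compound 4 is therefore expected to stay close to compound 3, with an expected step of a 1.1-fold lower number from compound 3 to compound 4 (0.03 log units; within the scatter) in this assay . The estimate for compound 4 is 9000 nM, with a range from 4500 nM to 18000 nM.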

Compound 4, half-maximal inhibitory concentration: 15500 nM
Compound 4: the middle estimate sits 1.7-fold (0.24 log units) below what was measured; low and high end bracket the measured number.
By their numbers in this assay, from the lowest: compounds 3, 2, 1 and 4 (each within the scatter of the next).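

Among the compounds shown here, compound 4 is the first compound here in which a group is added to the phenyl rather than one substituted phenyl being swapped for another. In this assay, placing chloro ortho to a fluoro group gives a 1.6-fold higher number from compound 3 to compound 4 (0.21 log units; within the scatter), the largest step in the set, yet it stays within the scatter. The comparisons with the other two compounds read the same way, with a 1.4-fold higher number from compound 2 to compound 4 (0.13 log units; within the scatter) and a 1.3-fold higher number from compound 1 to compound 4 (0.10 log units; within the scatter), so 3-chloro-4-fluorophenyl cannot be told apart from the other three phenyl groups in this assay, and nothing available explains the small differences seen among them.

Going by these compounds, all four compounds carry a phenyl with at least one halogen on the amide-type nitrogen, so it remains open whether an amine or a carboxylic acid on that phenyl, or a longer chain in its place, would move the number beyond the scatter. On these data alone, the rest of the shared core is the same in all four compounds, so the effect of changes there also remains open.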